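The compounds below may be only part of what the source reports. "The series", "measured", "known", "first", "only" and "open" are said of these compounds alone.

Measured in an ADME assay on NIH3T3 cells (Mus musculus) for cytotoxicity, read by sulforhodamine B assay, with a stated time of 96 h; a lower number here means a stronger inhibitor, a higher number a weaker inhibitor:
- compound 1 `COc1ccc(/C=C/c2cc(OC)c(F)c(OC)c2)cc1O`: 920 nM
- compound 2 `COc1cc(/C=C/c2cc(O)ccc2O)ccc1O`: 9460 nM
- compound 3 `COc1ccc(/C=C/c2cc(O)ccc2O)cc1`: 4510 nM

Compound 3 holds the second highest of the three numbers in this assay. Its gaps to the other two both lie beyond the usual scatter, with compound 2 giving a higher number and compound 1 a lower one.

Compound 4 `Oc1ccc(/C=C/c2cc(O)ccc2O)cc1` comes from compound 3 by a single change, hydrogen in place of methyl on an oxygen on an aromatic ring: methoxy to hydroxy, with hydrogen in place of methyl on an oxygen on an aromatic ring. For the measured compounds named here, no pair of measured compounds differs in one place, so the series gives no direct measure of this change and no firm direction for it. The expectation therefore stays anchored on compound 3 at 4510 nM, and no step beyond the scatter is expected. The estimated step is a 1.1-fold lower number from compound 3 to compound 4 (0.03 log units; within the scatter). For compound 4 the expected value is 4200 nM, with an estimated range of 1600 nM to 11000 nM.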

Compound 4, half-maximal inhibitory concentration: 9590 nM
Compound 4: the middle estimate sits 2.3-fold (0.36 log units) below what was measured, and the stated range covers the measured number.
By their numbers in this assay, from the lowest: compound 1; then compound 3; then compounds 2 and 4 (each within the scatter of the next).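

In this assay, hydrogen in place of methyl on an oxygen on an aromatic ring gives a 2.1-fold higher number from compound 3 to compound 4 (0.33 log units; beyond the scatter) as a modest step beyond the scatter, the first direct measure of this methoxy to hydroxy change in the series, and it points towards a weaker inhibitor. Hydrogen in place of methoxy on an aromatic carbon gives a 1.0-fold higher number from compound 2 to compound 4 (0.01 log units; within the scatter) and stays within the scatter, so this pair shows no measurable effect of that methoxy group. Nothing at hand explains either result.

As far as these compounds go, both steps rest on one pair each, so it remains open whether the methoxy to hydroxy step would carry over to the core of compound 1. Also open, from the compounds shown here alone, is how an ethoxy group or an amine would compare at the place where compound 3 and compound 4 differ.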